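This account rests on a few compounds, and the source may have more. Where it says the series, first, only, none or still open, it means among the compounds named here.

Measured compounds in a functional assay on HepG2 cells (Homo sapiens) for antiproliferative activity, read by MTT assay, with a stated time of 48 h; a higher number here means a weaker inhibitor, a lower number a stronger inhibitor:
compound 1 `CCCCCCOc1ccc(C(=O)/C=C/c2c(/C=C/c3ccc(OC)cc3)cc(OC)cc2OC)cc1` gives 16.2 ug/mL;
compound 2 `COc1ccc(/C=C/c2cc(OC)cc(OC)c2/C=C/C(=O)c2ccc(C(F)(F)F)cc2)cc1` gives 18.7 ug/mL;
compound 3 `CCCCCCCCCCCCOc1ccc(C(=O)/C=C/c2c(/C=C/c3ccc(OC)cc3)cc(OC)cc2OC)cc1` gives 11.6 ug/mL.

Compound 2 holds the highest of the three numbers, yet its gaps to compound 1 and to compound 3 both lie within the scatter, so no ordering among them can be read. Compound 4 `COc1ccc(/C=C/c2cc(OC)cc(OC)c2/C=C/C(=O)c2cccc(OC)c2)cc1` is unmeasured. Relative to compound 2 the change is 3-methoxyphenyl in place of 4-(trifluoromethyl)phenyl on a carbonyl carbon. The step of a 1.2-fold higher number from compound 1 to compound 2 (0.06 log units; within the scatter) exchanged the substituent on this same aryl ring and stayed within the scatter, as did a 1.4-fold lower number from compound 1 to compound 3 (0.15 log units; within the scatter), which altered only the chain. Both bearing steps therefore point to no change beyond the scatter in this assay. Compound 4 is expected to give 17 ug/mL, ranging from 9 ug/mL to 33 ug/mL. This estimate amounts to an expected step of a 1.1-fold lower number from compound 2 to compound 4 (0.04 log units; within the scatter).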

Compound 4, half-maximal inhibitory concentration: 11.6 ug/mL
For compound 4 the middle estimate is 1.5-fold (0.17 log units) above the measured one, within the range that was stated.
By their numbers in this assay, from the lowest: compounds 3, 4, 1 and 2 (each within the scatter of the next).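

In this assay the exchange of 4-(trifluoromethyl)phenyl for 3-methoxyphenyl on a carbonyl carbon gives a 1.6-fold lower number from compound 2 to compound 4 (0.21 log units; within the scatter) and so no readable gain or loss. This adds methoxy to hexyloxy, dodecyloxy and trifluoromethyl as substituents on this aryl ring, with no listed step among these compounds going beyond the scatter.

From the compounds shown here alone, whether an amine or a carboxylic acid on this ring would move the number beyond the scatter stays open. No measurement at hand accounts for this result.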